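From a hydrogen to hydroxymethyl on a triple bond

The source may report more compounds than this note shows. Statements on the series, on what has been measured and on what is new or still open speak of the compounds shown alone.

Compound 1 `COc1cc(Cc2nc3c(N)ncnc3n2CCCC#CCNCCCCNCC#CCCCn2c(Cc3cc(OC)c(OC)c(OC)c3)nc3c(N)ncnc32)cc(OC)c1OC`: > 100000 nM
Compound 2 `C#CCCCn1c(Cc2cc(OC)c(OC)c(OC)c2)nc2c(N)ncnc21`: 45900 nM

Both values come from a functional assay on MCF7 cells (Homo sapiens) for cytotoxicity, with a stated time of 24 h; a lower number here means a stronger inhibitor, a higher number a weaker inhibitor. The reading for compound 1 of > 100000 nM is a limit of the assay and not a number. Among the compounds with values here, compound 2, at 45900 nM, therefore holds the only true number in this small set, and there is no second number to rank it against.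

The next compound to be tested is compound 3 `COc1cc(Cc2nc3c(N)ncnc3n2CCCC#CCO)cc(OC)c1OC`, which keeps the shared core of compound 2 and differs in one place: hydroxymethyl in place of hydrogen on a triple-bonded carbon. Hydroxymethyl stands in place of hydrogen on a triple-bonded carbon, so the but-3-yn-1-yl chain becomes 5-hydroxypent-3-yn-1-yl.

Within the data shown here, no measured pair of compounds shows what this change does, so the starting point for any expectation is compound 2 at 45900 nM. The expected step of a 1.2-fold higher number from compound 2 to compound 3 (0.08 log units; within the scatter) in this assay is small, leaning towards a weaker inhibitor and possibly staying within the usual scatter. For compound 3 the estimate is 55000 nM, with an expected range of 22000 nM to 100000 nM.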

Compound 3, half-maximal inhibitory concentration: > 100000 nM
Compound 3: a limit, no number; the forecaster's own chance of this, stated with the estimate: 25%; at least 1.8-fold (0.25 log units) between middle value and limit.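

Hydroxymethyl in place of hydrogen on a triple-bonded carbon is the first single change in this set that can be read, and it does not leave activity intact. In this assay, turning the but-3-yn-1-yl chain into 5-hydroxypent-3-yn-1-yl gives an at least 2.1-fold higher number from compound 2 to compound 3 (0.33 log units; beyond the scatter), so the loss of activity lies beyond the usual scatter, and this end of the chain does not accept the change without cost. Compound 3 gives > 100000 nM, which is a limit of the assay and not a number, so the step marks only the smallest possible size of the change, and its true size cannot be read: the limit of > 100000 nM in this assay, at which 2 of the 3 values shown sit.

The compounds shown leave open whether the added carbon or the added hydroxyl goes with the weaker reading, a question that a methyl group on the same triple-bonded carbon would help to separate. Also open, as far as these compounds go, is how an aminomethyl group, a carboxylic acid or a longer chain ending in hydroxyl would read at this position.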